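A few compounds are considered here, and "the series" means these few. Any claim that something is new, unique, unknown or untested is made for them only; others in the source may bear on it.

Compound 1 `COc1ccc(Nc2cccc3c2C(=O)N(C2CCC(=O)NC2=O)C3=O)cc1` gives 13% in an assay on FRT-Jurkat cells for inhibition of nuclear factor NF-kappa-B complex (Homo sapiens), read by flow cytometry, with a stated time of 24 h, tested at 10 uM; on this read-out lower numbers stand for less inhibition and higher numbers for more inhibition at the one concentration tested (going by the name of the read-out).
Compound 2 `C=C(OCC)c1ccc(Nc2cccc3c2C(=O)N(C2CCC(=O)NC2=O)C3=O)cc1` gives 10% in this assay.

Compound 2 and compound 1 sit within the scatter of each other, so neither can be put above the other on these numbers. Compound 3 `CCCCCc1ccc(Nc2cccc3c2C(=O)N(C2CCC(=O)NC2=O)C3=O)cc1` has not yet been measured; it differs from compound 2 in one place: pentyl in place of 1-ethoxyethenyl on an aromatic carbon. Going by the values given here, the single measured step that bears on this is a number 3 percentage points lower from compound 1 to compound 2 (within the scatter), which also exchanged the group on this aromatic carbon and stayed within the scatter. With both measured compounds close to one another and no sign that this position matters, compound 3 is expected to show no step beyond the scatter in this assay, that is a number 1 percentage points higher from compound 2 to compound 3 (within the scatter). The estimate for compound 3 is therefore 11%, with a range from 0% to 25%.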

Compound 3, a percentage reported as inhibition, at one concentration (the size of the read-out at that concentration, not a potency): 23%
Beside the measured number, compound 3's estimate is 12 percentage points below it, within the range that was stated.
By their numbers in this assay, from the lowest: compounds 2, 1 and 3 (each within the scatter of the next, the first and the last beyond it).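

In this assay, going by these compounds alone, exchanging 1-ethoxyethenyl for pentyl gives a number 13 percentage points higher from compound 2 to compound 3 (beyond the scatter), the first step at this aromatic carbon to clear the scatter, so the group placed here can make a modest difference to the read-out. Exchanging methoxy for pentyl gives a number 10 percentage points higher from compound 1 to compound 3 (within the scatter), so the pentyl group stands apart from only one of the two earlier groups. Nothing shown here offers an explanation for this difference.

The step from 1-ethoxyethenyl to pentyl removes the oxygen and the double bond together, so these compounds cannot show whether either one alone accounts for it. Going by these compounds, it also remains open how a plain ethyl group, a longer chain such as octyl, an amine or a carboxylic acid at this carbon would read in this assay.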